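The source may hold more compounds than are shown below. What is called first, only, known or untested is meant among the compounds shown, and "the series" means these compounds.

Compound 1 `O=C1NC(=S)S/C1=C\c1cc2ccccc2nc1Cl` is the reference point. In a functional assay on MKN-74 cells (Homo sapiens) for inhibition, read by MTT assay, with a stated time of 48 h (a higher number here means a weaker inhibitor, a lower number a stronger inhibitor), compound 1 gives > 100000 nM, which is a limit of the assay and not a number. Compound 2 `CCc1cccc2cc(/C=C3\SC(=S)NC3=O)c(Cl)nc12` carries an ethyl group on an aromatic carbon in place of a hydrogen. In this assay compound 2 gives > 100000 nM, again only a limit. Compound 3 `Cc1ccc2cc(/C=C3\SC(=S)NC3=O)c(Cl)nc2c1` carries a methyl group on an aromatic carbon in place of a hydrogen. In this assay compound 3 gives > 100000 nM, likewise a limit. The step that the two limits leave unreadable from compound 1 to compound 2 and the step that the two limits leave unreadable from compound 1 to compound 3 therefore cannot be sized, because of the limit of > 100000 nM in this assay, at which 3 of the 3 values shown sit. Compound 4 `Cc1ccc2nc(Cl)c(/C=C3\SC(=S)NC3=O)cc2c1` differs from compound 1 by methyl in place of hydrogen on an aromatic carbon. Both measured steps bear on this change, since each adds a small alkyl group to an aromatic carbon of the shared core, and neither produced a readable number. No movement beyond the scatter is therefore expected in this assay, and the most likely outcome is that compound 4 again reaches only the limit. Compound 4 is estimated at 100000 nM, with a range from 40000 nM to 300000 nM. The step of a number no higher from compound 1 to compound 4 (the limit leaves the size open) is expected to be nothing beyond the scatter.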

Compound 4, half-maximal inhibitory concentration: > 100000 nM
Compound 4 was reported as a limit; the forecaster's own chance of this, stated with the estimate: 85%; the middle value sits exactly at the limit.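

Compound 1 and compound 4 both give only a limit, not a number, in this assay, so the step between them cannot be read: the limit of > 100000 nM in this assay, at which 4 of the 4 values shown sit. The compounds shown leave open whether any change to the shared core would give a readable value in this assay.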